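This account rests on a few compounds, and the source may have more. Where it says the series, first, only, none or still open, it means among the compounds named here.

Among the compounds with values here, compound 1 `CCC[C@@H](NC(=O)c1cnccn1)C(=O)N[C@@H](CC(C)C)B(O)O` is the stronger of the two compounds measured so far. In an assay on isolated protein for inhibition of Lon protease homolog, mitochondrial (Homo sapiens), read by HTRF, with a stated time of 50 min, in the presence of a further agent that is not named here (a higher number here means a weaker inhibitor, a lower number a stronger inhibitor), compound 1 gives 187 nM, the lowest of the two numbers. Within the data shown here, compound 2 `CC(C)C[C@H](NC(=O)[C@H](NC(=O)c1cnccn1)C(C)(C)C)B(O)O` gives 2850 nM in this assay, and the single measured step, a 15-fold higher number from compound 1 to compound 2 (1.18 log units; beyond the scatter), involves tert-butyl in place of propyl on a saturated chain carbon bound to an amide-type nitrogen and a carbonyl carbon.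

Compound 3 `CCC[C@@H](NC(=O)c1cnccn1)C(=O)N[C@@H](CC1CCCCC1)B(O)O` differs from compound 1 elsewhere: cyclohexyl in place of isopropyl on a saturated chain carbon, two bonds along the chain from an amide-type nitrogen and a boron atom. Among the measured compounds shown here, no measured step touches this part of the shared core, so the step from compound 1 to compound 2 does not bear on it directly, and nothing here shows how the carbon bound to boron tolerates a bulkier group. For the measured compounds named here, with no step to lean on, the change is expected to produce no step beyond the scatter, a 1.3-fold higher number from compound 1 to compound 3 (0.13 log units; within the scatter), in this assay. Compound 3 is therefore estimated at 250 nM, with a range from 80 nM to 800 nM.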

Compound 3, half-maximal inhibitory concentration: 136 nM
The estimate for compound 3 lay 1.8-fold (0.26 log units) above the measured number, within the range that was stated.
By their numbers in this assay, from the lowest: compounds 3 and 1 (each within the scatter of the next); then compound 2.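

Putting cyclohexyl in place of isopropyl, on a saturated chain carbon two bonds along the chain from an amide-type nitrogen and a boron atom, gives a 1.4-fold lower number from compound 1 to compound 3 (0.14 log units; within the scatter) in this assay. This position therefore accepts a group of 6 heavy atoms, closed into a six-membered ring, where compound 1 carries 3 heavy atoms and no ring, with no difference in the assay beyond the usual scatter. Nothing available explains why the larger group is accepted here.

As far as these compounds go, whether the same position also accepts a phenyl ring, an amine, a carboxylic acid or a longer chain remains open. Also open is how cyclohexyl behaves when combined with the tert-butyl group of compound 2, since each of these changes is shown only on its own.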